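Pyridin-3-yl in place of cyclohexyl on the chain

A few compounds are considered here, and "the series" means these few. Any claim that something is new, unique, unknown or untested is made for them only; others in the source may bear on it.

In an ADME assay on MDBK cells (Bos taurus) for cytotoxicity (on this read-out lower numbers stand for higher toxicity in this test and higher numbers for lower toxicity in this test), compound 2 `c1ccc(-c2nc3ccn(CC4CCCCC4)cc-3n2)cc1` gives > 100000 nM as a limit and not a number. Compound 1 `Cc1ccc(Cn2ccc3nc(-c4ccccc4)nc-3c2)cc1` gives > 100000 nM as a limit too. Compound 3 `c1ccc(-c2nc3ccn(Cc4cccnc4)cc-3n2)cc1` carries pyridin-3-yl in place of cyclohexyl on a saturated chain carbon bound to an aromatic nitrogen and remains unmeasured. Among the measured compounds shown here, the one measured step at this place is a step that the two limits leave unreadable from compound 1 to compound 2 and its size cannot be read, so the series offers only the limit of > 100000 nM in this assay, at which 2 of the 2 values shown sit, as a guide. No change beyond the scatter is expected in this assay and the estimated step is a number no higher from compound 2 to compound 3 (the limit leaves the size open) without a favoured direction. Compound 3 is expected at 100000 nM with an estimated range from 40000 nM to 200000 nM in this read-out.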

Compound 3, half-maximal cytotoxic concentration: > 100000 nM
Compound 3: only a limit was reported (the forecaster's own chance of this, stated with the estimate: 85%); the middle value sits exactly at the limit.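

No step among compound 1, compound 2 and compound 3 can be read in this assay, as each value is a limit and not a number: the limit of > 100000 nM in this assay, at which 3 of the 3 values shown sit.

The compounds shown leave open whether 4-methylphenyl, cyclohexyl and pyridin-3-yl on the chain differ at all on this read-out.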